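Dimethoxyphenyl Analogue of a Pyrazole Chalcone Amine

A few compounds are considered here, and "the series" means these few. Any claim that something is new, unique, unknown or untested is made for them only; others in the source may bear on it.

Measured compounds:
compound 1 `COc1ccc(-c2cc(/C=C/C(=O)c3ccc(N)cc3)[nH]n2)cc1` gives 56200 nM in a functional assay on SW-620 cells (Homo sapiens) for inhibition, read by sulforhodamine B assay, with a stated time of 48 h; on this read-out lower numbers stand for higher toxicity in this test and higher numbers for lower toxicity in this test
compound 2 `COc1cc(-c2cc(/C=C/C(=O)c3ccc(Cl)c(Cl)c3)[nH]n2)cc(OC)c1OC` gives > 100000 nM in this assay

Compound 1 holds the only number shown in this assay. The value of compound 2 in this assay is a limit of the test and not a number, as recorded at the limit of > 100000 nM in this assay, at which 1 of the 2 values shown sits.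

Compound 3 `COc1ccc(-c2cc(/C=C/C(=O)c3ccc(N)cc3)[nH]n2)cc1OC` differs from compound 1 by methoxy in place of hydrogen on an aromatic carbon, on the aromatic carbon ortho to a methoxy group. Among the compounds with values here, with no measured step to lean on, a change no larger than the usual scatter is expected, in either direction. Compound 3 is therefore estimated at 70000 nM, between 25000 nM and 150000 nM, a step of a 1.2-fold higher number from compound 1 to compound 3 (0.10 log units; within the scatter).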

Compound 3, concentration lethal to 50% of the cells: 82900 nM
For compound 3 the middle estimate is 1.2-fold (0.07 log units) below the measured one; the measured number falls inside the stated range.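

Methoxy in place of hydrogen on the aromatic carbon ortho to a methoxy group gives a 1.5-fold higher number from compound 1 to compound 3 (0.17 log units; within the scatter) in this assay and is the first step shown between compounds that differ in one place. At this position, the added methoxy leaves the number within the scatter. Nothing shown gives a reason for this step. The compounds shown leave open whether an amine, a hydroxyl group or a longer chain such as ethoxy on this same aromatic carbon would move the number beyond the scatter.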